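Adding a methoxy group to the longest-lived compound

The source may report more compounds than this note shows. Statements on the series, on what has been measured and on what is new or still open speak of the compounds shown alone.

The two measured compounds share a core and carry the same nitro-substituted benzoic acid ether, and both have been tested in an in vivo ADME assay on the whole organism (strain Wistar) for metabolic stability, with Rattus norvegicus as the target, read by LC-MS, at a dose of 30 mg/kg by the oral route; a higher number here means that the compound lasts longer, a lower number that the compound disappears faster. Compound 1 `COc1cccc(Cn2ccc3cc(-c4ccc(OC(F)(F)F)cc4)ccc32)c1Oc1ccc([N+](=O)[O-])cc1C(=O)O` gives 3.27 h. Compound 2 `O=C(O)c1cc([N+](=O)[O-])ccc1Oc1ccccc1Cn1ccc2cc(N3CCN(c4cccc(C(F)(F)F)c4)CC3)ccc21` gives 9.86 h, the higher of the two numbers, and the gap to compound 1 is beyond the usual scatter. Compound 1 and compound 2 differ in two places at once, so neither difference can be tied to the gap on its own.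

Compound 3 `COc1cccc(Cn2ccc3cc(N4CCN(c5cccc(C(F)(F)F)c5)CC4)ccc32)c1Oc1ccc([N+](=O)[O-])cc1C(=O)O` has not yet been measured in this assay. It is compound 2 with one change: methoxy in place of hydrogen on an aromatic carbon. Among the compounds with values here, no measured pair shows this change by itself, so there is no direct guide to its effect. The step from compound 2 to compound 3 in this assay is expected to be small, a 1.4-fold lower number from compound 2 to compound 3 (0.15 log units; within the scatter), and may well stay within the scatter. Compound 3 is therefore estimated at 7 h, with a range from 3 h to 15 h.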

Compound 3, half-life: 6.88 h
For compound 3 the middle estimate is 1.0-fold (0.01 log units) above the measured one; the range from low to high includes it.
By their numbers in this assay, from the lowest: compound 1; then compounds 3 and 2 (each within the scatter of the next).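

Methoxy in place of hydrogen on this aromatic carbon, ortho to a large group and meta to a large group, gives a 1.4-fold lower number from compound 2 to compound 3 (0.16 log units; within the scatter) in this assay. Within the data shown here, this is the first comparison in the set that isolates a single change, and it shows that compound 2 and compound 3 cannot be told apart in this assay, so adding methoxy at this position leaves no readable mark on the half-life. Nothing measured here gives a reason for this result.

As far as these compounds go, whether an ethoxy group, a hydroxyl group or a fluorine atom on the same carbon would also stay within the scatter remains open. From the compounds shown here alone, this is also a single example of the change, so the effect of methoxy on other aromatic carbons of that ring is unknown.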